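Removing a Trifluoromethyl: From Compound 3 to Compound 4

The source may hold more compounds than are shown below. What is called first, only, known or untested is meant among the compounds shown, and "the series" means these compounds.

Three compounds sharing one core were tested in a functional assay on Hs-578T cells (Homo sapiens) for inhibition, read by sulforhodamine B assay, with a stated time of 48 h, tested at 100 uM; a lower number here means a stronger effect, a higher number a weaker effect of the compound at the concentration tested. Compound 1 `O=C(Nc1cccc(-n2cc(-c3ccncc3)c(-c3cc(O)cc(Cl)c3)n2)c1)Nc1ccc(Cl)c(C(F)(F)F)c1` gives 1%, and compound 2 `O=C(Nc1cccc(-n2cc(-c3ccncc3)c(-c3cc(O)cc(Cl)c3)n2)c1)Nc1ccc(Cl)c(Cl)c1` gives 9%; the step of a number 8 percentage points higher from compound 1 to compound 2 (within the scatter) lies within the scatter. Compound 3 `COc1cc(Cl)cc(-c2nn(-c3cccc(NC(=O)Nc4cc(C(F)(F)F)cc(C(F)(F)F)c4)c3)cc2-c2ccncc2)c1` gives -25%, the lowest of the three numbers, with compound 1 nearest and compound 2 furthest, both gaps beyond the scatter. Compound 4 `COc1cc(Cl)cc(-c2nn(-c3cccc(NC(=O)Nc4cccc(C(F)(F)F)c4)c3)cc2-c2ccncc2)c1` differs from compound 3 in one place: hydrogen in place of trifluoromethyl on an aromatic carbon. Within the data shown here, no measured step removes a trifluoromethyl outright; the only step available, a number 8 percentage points higher from compound 1 to compound 2 (within the scatter), exchanges one for chloro and changes little, so only a modest rise, if any, is expected. Compound 4 is therefore estimated at -10%, between -35% and 15%, a step of a number 15 percentage points higher from compound 3 to compound 4 (beyond the scatter).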

Compound 4, a percentage reported as activity, at one concentration (the size of the read-out at that concentration, not a potency): 21%
Compound 4: middle estimate off by 31 percentage points, on the low side, and the stated range ends below it.
By their numbers in this assay, from the lowest: compound 3; then compounds 1 and 2 (each within the scatter of the next); then compound 4.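

In this assay, leaving hydrogen on this aromatic carbon, meta to a trifluoromethyl group, gives a number 46 percentage points higher from compound 3 to compound 4 (beyond the scatter) and so a clearly weaker effect at the concentration tested. Among these compounds, the position therefore responds strongly to losing its trifluoromethyl, which the only earlier step, a number 8 percentage points higher from compound 1 to compound 2 (within the scatter) on a different pair with chloro entering, did not show. No available evidence explains the size of this step. From the compounds shown here alone, whether chloro, an amine or a carboxylic acid on this carbon would keep the effect of compound 3 remains open.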